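Urea Arm Replaces Benzyl on a Weak Scaffold

This account rests on a few compounds, and the source may have more. Where it says the series, first, only, none or still open, it means among the compounds named here.

Within the data shown here, compound 1 `NC(=O)c1c(NC(=O)c2ccccc2Cl)sc2c1CCN(Cc1ccccc1F)C2` is the only compound in this set with a measured number: in a functional assay on HL-60 cells (Homo sapiens) for antiproliferative activity, with a stated time of 24 h (a higher number here means a weaker inhibitor, a lower number a stronger inhibitor), compound 1 gives 21800 nM. Compound 2 `NC(=O)c1c(NC(=O)c2ccc(C(F)(F)F)cc2)sc2c1CCN(Cc1ccccc1F)C2` carries 4-(trifluoromethyl)phenyl in place of 2-chlorophenyl on a carbonyl carbon. In this assay compound 2 gives > 50000 nM, which is a limit of the assay and not a number. Among the measured compounds shown here, that change produced an at least 2.2-fold higher number from compound 1 to compound 2 (0.36 log units; beyond the scatter), the one measured step, resting on (the limit of > 50000 nM in this assay, at which 1 of the 2 values shown sits).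

Compound 3 `NC(=O)c1c(NC(=O)c2ccccc2Cl)sc2c1CCN(C(=O)Nc1ccccc1Cl)C2` differs from compound 1 on the other side of the shared core: (2-chlorophenyl)carbamoyl in place of 2-fluorobenzyl on an amine nitrogen in a ring. The measured step concerns the benzamide side, not the amine nitrogen in the ring, so no measured comparison bears on this change; what the data show is that the shared core sits at weak potency. Compound 3 is therefore expected to stay near compound 1, with an estimated step of a 1.4-fold higher number from compound 1 to compound 3 (0.14 log units; within the scatter) in this assay that need not exceed the scatter. The estimate for compound 3 is 30000 nM, expected to fall between 8000 nM and 100000 nM, with a real chance that only a limit is returned.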

Compound 3, half-maximal inhibitory concentration: 12500 nM
Compound 3: middle estimate off by 2.4-fold (0.38 log units), on the high side; low and high end bracket the measured number.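

In this assay, (2-chlorophenyl)carbamoyl in place of 2-fluorobenzyl on the amine nitrogen in a ring gives a 1.7-fold lower number from compound 1 to compound 3 (0.24 log units; within the scatter) and so leaves the two compounds indistinguishable. Among these compounds, this is the first measured view of that position, and it shows that a large exchange there, bringing in a carbonyl and the amide hydrogen while keeping one six-membered aromatic ring of carbon only, leaves potency in the same weak range and still returns a number rather than a limit. No measurement shown here accounts for this result.

What the compounds shown leave open is whether the amine nitrogen in a ring can move potency at all, since both groups compared there carry a halogen-bearing phenyl ring, and a carboxylic acid or a basic amine on that ring, or a longer chain leading to it, could tell more. Also open, on these data alone, is how the urea arm behaves with the 4-(trifluoromethyl)phenyl group on the other side of the shared core.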